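Removing the ortho hydroxy from the hydrazone aryl of compound 3

The source may hold more compounds than are shown below. What is called first, only, known or untested is meant among the compounds shown, and "the series" means these compounds.

Measured so far:
compound 1 `O=C(N/N=C/c1ccc(O)cc1)c1ccc(-c2nc3ccccc3s2)cc1` — 11300 nM
compound 2 `COc1ccc(/C=N/NC(=O)c2ccc(-c3nc4ccccc4s3)cc2)c(O)c1` — 6970 nM
compound 3 `O=C(N/N=C/c1ccccc1O)c1ccc(-c2nc3ccccc3s2)cc1` — 5550 nM

In an assay on isolated protein for inhibition of Maltase-glucoamylase (Homo sapiens), with a stated time of 15 min (a higher number here means a weaker inhibitor, a lower number a stronger inhibitor), compound 3 gives the lowest number of the three; compound 2 sits within the scatter of it, while compound 1 stands apart, as a 2.0-fold lower number from compound 1 to compound 3 (0.31 log units; beyond the scatter) shows. Compound 4 `O=C(N/N=C/c1ccccc1)c1ccc(-c2nc3ccccc3s2)cc1` differs from compound 3 by hydrogen in place of hydroxy on an aromatic carbon, ortho to a large group; cut one bond further out the change reads 2-hydroxyphenyl to phenyl. For the measured compounds named here, no measured step removes this hydroxy. The nearest comparisons are a 1.3-fold lower number from compound 2 to compound 3 (0.10 log units; within the scatter), a methoxy taken off the same ring, and a 2.0-fold lower number from compound 1 to compound 3 (0.31 log units; beyond the scatter); both are small, and no change on this ring has yet given a large step. For compound 4 a small rise in the number is expected, a 1.5-fold higher number from compound 3 to compound 4 (0.19 log units; within the scatter). The estimate for compound 4 is 8500 nM, range 4000 nM to 18000 nM.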

Compound 4, half-maximal inhibitory concentration: 8050 nM
The estimate for compound 4 lay 1.1-fold (0.02 log units) above the measured number, and the stated range covers the measured number.
By their numbers in this assay, from the lowest: compounds 3, 2, 4 and 1 (each within the scatter of the next, the first and the last beyond it).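

In this assay, hydrogen in place of hydroxy stays within the scatter whether the hydroxy leaves the 2-hydroxyphenyl (a 1.5-fold higher number from compound 3 to compound 4 (0.16 log units; within the scatter)) or the 4-hydroxyphenyl (a 1.4-fold lower number from compound 1 to compound 4 (0.15 log units; within the scatter)), so neither hydroxy is shown to matter on this ring. Plain phenyl also stays within the scatter of 2-hydroxy-4-methoxyphenyl (a 1.2-fold higher number from compound 2 to compound 4 (0.06 log units; within the scatter)). No supporting data explain these small steps.

Open, on these data alone, is whether an amine or a carboxylic acid on this ring would give a step beyond the scatter. Also open, as far as these compounds go, is whether any change to the shared core would do so.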